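A Bromo Swap in a Series Held at the Limit

The source may hold more compounds than are shown below. What is called first, only, known or untested is meant among the compounds shown, and "the series" means these compounds.

In a functional assay on CEM-SS cells (Homo sapiens) for cytotoxicity (a higher number here means a weaker inhibitor, a lower number a stronger inhibitor), compound 1 `Clc1ccc(Cn2c(Cl)nc3cc(Cl)c(Cl)cc32)cc1` gives > 100000 nM as a limit. Compound 2 `Clc1ccc(Cn2c(Cl)nc3cc(Cl)c(Cl)cc32)cc1Cl` gives > 100000 nM as a limit too. Compound 3 `Clc1cccc(Cn2c(Cl)nc3cc(Cl)c(Cl)cc32)c1` gives > 100000 nM as a limit as well. Compound 2 therefore stands only at the limit of > 100000 nM in this assay, at which 3 of the 3 values shown sit, and has no number of its own. Compound 4 `Clc1ccc(Cn2c(Br)nc3cc(Cl)c(Cl)cc32)cc1Cl` departs from compound 2 by a single change bromo in place of chloro on an aromatic carbon and by nothing else. The measured steps bearing on it are a step that the two limits leave unreadable from compound 1 to compound 2 and a step that the two limits leave unreadable from compound 2 to compound 3 and both only exchange chloro with hydrogen. Neither has a readable size, so no direction can be carried over, and the expected a number no higher from compound 2 to compound 4 (the limit leaves the size open) stays within the scatter. Compound 4 is estimated at 100000 nM with a range from 40000 nM to 200000 nM and will probably be reported as a limit again.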

Compound 4, half-maximal inhibitory concentration: > 100000 nM
Compound 4 ended at the assay's limit (the forecaster's own chance of this, stated with the estimate: 85%); the middle value sits exactly at the limit.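

Going by these compounds alone, compound 4, like compound 2, stands only as a limit in this assay, so no step between compound 2 and compound 4 can be read. The compounds shown leave open whether bromo and chloro differ at all here.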